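A few compounds are considered here, and "the series" means these few. Any claim that something is new, unique, unknown or untested is made for them only; others in the source may bear on it.

Compound 2 `O=C(NCCCCc1ccccc1)c1cccc(C2SCC(=O)N2c2ccccc2)c1` stands second highest of the three numbers in a functional assay on SJSA-1 cells (Homo sapiens) for inhibition, read by CCK-8 assay, with a stated time of 72 h, tested at 1 uM (on this read-out higher numbers stand for more inhibition at the one concentration tested (going by the name of the read-out) and lower numbers for less inhibition), where compound 2 gives 73%. Compound 3 `O=C(NCCCCc1ccccc1)c1cccc(C2SCC(=O)N2c2cccc(F)c2)c1` gives 80%, and the step of a number 7 percentage points higher from compound 2 to compound 3 (within the scatter) stays within the scatter. Compound 1 `COc1ccc(OC)c(N2C(=O)CSC2c2cccc(C(=O)NCCCCc3ccccc3)c2)c1` gives 48%, and the step of a number 25 percentage points higher from compound 1 to compound 2 (beyond the scatter) lies beyond it. Compound 4 `COc1c(F)cccc1N1C(=O)CSC1c1cccc(C(=O)NCCCCc2ccccc2)c1` differs from compound 2 in one place: 3-fluoro-2-methoxyphenyl in place of phenyl on an amide-type nitrogen in a ring. Both earlier steps bear on this: the fluoro in a number 7 percentage points higher from compound 2 to compound 3 (within the scatter) changed little, while the methoxy-bearing compound 1 sits far lower in a number 25 percentage points higher from compound 1 to compound 2 (beyond the scatter). Because compound 1 gives 48%, compound 4 is expected to drop by a number 15 percentage points lower from compound 2 to compound 4 (beyond the scatter), less than two methoxy groups did. Compound 4 is therefore estimated at 58%, within 40% to 75%.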

Compound 4, a percentage reported as inhibition, at one concentration (the size of the read-out at that concentration, not a potency): 1%
For compound 4 the middle estimate is 57 percentage points above the measured one; the measured number lies below the stated range.
By their numbers in this assay, from the lowest: compound 4; then compound 1; then compounds 2 and 3 (each within the scatter of the next).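

In this assay the effects on this aryl group on the amide-type nitrogen do not simply add up: with fluoro already present, methoxy in place of hydrogen gives a number 79 percentage points lower from compound 3 to compound 4 (beyond the scatter). The 3-fluoro-2-methoxyphenyl group also falls well short of the 2,5-dimethoxyphenyl group, with a number 47 percentage points lower from compound 1 to compound 4 (beyond the scatter), and against plain phenyl it gives a number 72 percentage points lower from compound 2 to compound 4 (beyond the scatter), so the number of methoxy groups alone does not set the read-out here. Nothing at hand explains this loss.

The compounds shown leave open whether a phenyl carrying methoxy without the fluoro would lose as much. They also leave open how a hydroxy group or an amine in place of that methoxy would read.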